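The source may hold more compounds than are shown below. What is called first, only, known or untested is meant among the compounds shown, and "the series" means these compounds.

Compound 1 `COc1ccc(C(=O)/C=C/c2ccc(F)cc2)c2c1C=CC(C)(C)O2` opens the set. In a functional assay on HT-29 cells (Homo sapiens) for antiproliferative activity, read by MTT assay, with a stated time of 24 h (a higher number here means a weaker inhibitor, a lower number a stronger inhibitor), compound 1 gives only a limit, > 10000 nM, not a number. Compound 2 `COc1ccc(C(=O)/C=C/c2cccc(F)c2)c2c1C=CC(C)(C)O2` likewise gives a limit in this assay, > 10000 nM. Compound 3 `COc1ccc(C(=O)/C=C/c2ccsc2)c2c1C=CC(C)(C)O2` also sits at a limit in this assay, > 10000 nM. The steps a step that the two limits leave unreadable from compound 1 to compound 2, a step that the two limits leave unreadable from compound 1 to compound 3 and a step that the two limits leave unreadable from compound 2 to compound 3 are therefore not readable, all three values resting at the limit of > 10000 nM in this assay, at which 3 of the 3 values shown sit. Compound 4 `COc1ccc(C(=O)/C=C/c2ccc(Cl)cc2)c2c1C=CC(C)(C)O2` differs from compound 1 by chloro in place of fluoro on an aromatic carbon. Going by the values given here, no measured step bears on chloro in place of fluoro, and the three aryl variants of the shared core have yielded nothing but limits. The expected step is a step that the limit leaves unreadable from compound 1 to compound 4, a further limit being the likelier outcome. Compound 4 is estimated at 12000 nM, between 3000 nM and 50000 nM.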

Compound 4, half-maximal inhibitory concentration: > 10000 nM
Compound 4 ended at the assay's limit (the forecaster's own chance of this, stated with the estimate: 75%); the middle value lies beyond the limit too.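

Steps among compound 1, compound 2, compound 3 and compound 4 cannot be read, because all four rest at one limit: the limit of > 10000 nM in this assay, at which 4 of the 4 values shown sit.

The compounds shown leave open how the aryl group on this shared core affects potency in this assay, since none gives a number there.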